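A few compounds are considered here, and "the series" means these few. Any claim that something is new, unique, unknown or untested is made for them only; others in the source may bear on it.

Compounds measured so far:
Compound 1, `COc1ncc(-c2ccc3nc(NC(=O)NC4CC4)nn3c2)cc1NS(=O)(=O)c1ccc(F)cc1`: 210 nM
Compound 2, `CCN(CC)CCNC(=O)Nc1nc2ccc(-c3cnc(OC)c(NS(=O)(=O)c4ccc(C)cc4)c3)cn2n1`: 730 nM
Compound 3, `CNC(=O)Nc1nc2ccc(-c3cnc(OC)c(NS(=O)(=O)c4ccc(F)cc4)c3)cn2n1`: 230 nM

In a functional assay on A549 cells (Homo sapiens) for cytotoxicity, read by MTT assay, with a stated time of 72 h (on this read-out higher numbers stand for weaker inhibition and lower numbers for stronger inhibition), compound 1 gives the lowest of the three numbers; compound 3 sits within the scatter of it, while compound 2 gives a number beyond the scatter. Compound 4, `COc1ncc(-c2ccc3nc(NC(=O)NCC(=O)N4CCCCC4)nn3c2)cc1NS(=O)(=O)c1ccc(F)cc1`, is not yet measured. It differs from compound 1 in one place: ((piperidin-1-yl)carbonyl)methyl in place of cyclopropyl on an amide-type nitrogen. Going by the values given here, the only measured step at that nitrogen, a 1.1-fold higher number from compound 1 to compound 3 (0.04 log units; within the scatter), was within the scatter, so a small change there left the number alone. Compound 2 carries a longer chain at the same urea and a different sulfonyl ring, and its number stands beyond the scatter from compound 1. On that basis compound 4 is expected to give a somewhat higher number, a 2.1-fold higher number from compound 1 to compound 4 (0.33 log units; beyond the scatter), estimated at 450 nM with a range from 180 nM to 1200 nM.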

Compound 4, half-maximal inhibitory concentration: 2060 nM
Estimate against measurement, compound 4: 4.6-fold (0.66 log units) below; the measured number lies above the stated range.
By their numbers in this assay, from the lowest: compounds 1 and 3 (each within the scatter of the next); then compound 2; then compound 4.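

In this assay, the amide-type nitrogen that showed no change from cyclopropyl to methyl proves sensitive to a larger substituent: ((piperidin-1-yl)carbonyl)methyl in place of cyclopropyl gives a 9.8-fold higher number from compound 1 to compound 4 (0.99 log units; beyond the scatter). Likewise, (piperidin-1-yl)carbonyl in place of hydrogen on the saturated chain carbon bound to that nitrogen gives a 9.0-fold higher number from compound 3 to compound 4 (0.95 log units; beyond the scatter). Nothing available explains this rise. The compounds shown leave open whether the carbonyl or the piperidin-1-yl group accounts for these steps. A 2-(piperidin-1-yl)ethyl chain or a plain butyl chain on the same nitrogen would help separate the two.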